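Removing the pyrimidine from compound 2

A few compounds are considered here, and "the series" means these few. Any claim that something is new, unique, unknown or untested is made for them only; others in the source may bear on it.

Within the data shown here, in a functional assay on NCI-H460 cells (Homo sapiens) for antiproliferative activity, read by sulforhodamine B assay, with a stated time of 72 h (on this read-out higher numbers stand for weaker inhibition and lower numbers for stronger inhibition), compound 2 `Cc1cc(C)nc(NS(=O)(=O)c2ccc(Nc3nncc4ccccc34)cc2)n1` gives 0.8 nM, the lowest of the three numbers so far. Compound 1 `O=C1CS/C(=N/Nc2nncc3ccccc23)N1c1ccccc1` gives 30 nM, and compound 3 `O=C1CS/C(=N/Nc2nncc3ccccc23)N1` gives 19 nM. Compound 4 `NS(=O)(=O)c1ccc(Nc2nncc3ccccc23)cc1` differs from compound 2 by one change, hydrogen in place of 4,6-dimethylpyrimidin-2-yl on a sulfonamide nitrogen. Among the measured compounds shown here, the only measured step of a similar kind, a 1.6-fold lower number from compound 1 to compound 3 (0.20 log units; within the scatter), puts hydrogen in place of phenyl, but on an amide-type nitrogen in a ring, so it offers limited guidance. Since that step stays within the scatter, no large jump is predicted, yet such a low starting number leaves more room to rise than to fall. The expected change in this assay is a modest rise, an estimated 5.0-fold higher number from compound 2 to compound 4 (0.70 log units; beyond the scatter). Compound 4 is expected at 4 nM, with an estimated range of 0.8 nM to 20 nM.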

Compound 4, half-maximal inhibitory concentration: 17 nM
Beside the measured number, compound 4's estimate is 4.3-fold (0.63 log units) below it; low and high end bracket the measured number.
By their numbers in this assay, from the lowest: compound 2; then compounds 4, 3 and 1 (each within the scatter of the next).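

On a sulfonamide nitrogen, replacing 4,6-dimethylpyrimidin-2-yl with hydrogen gives a 21-fold higher number from compound 2 to compound 4 (1.33 log units; beyond the scatter) in this assay, so the low number of compound 2 depends on this group. The earlier change of a ring group to hydrogen, a 1.6-fold lower number from compound 1 to compound 3 (0.20 log units; within the scatter), sat on an amide-type nitrogen and stayed within the scatter. Losing a ring group therefore has no single size of effect across these compounds; it differs from one place to the other.

On these data alone, whether methyl or pyridin-2-yl on the sulfonamide nitrogen would give a number nearer compound 2 or compound 4 remains open. No measurement at hand explains the size of this step.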